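A few compounds are considered here, and "the series" means these few. Any claim that something is new, unique, unknown or untested is made for them only; others in the source may bear on it.

In a functional assay on HepG2 cells (Homo sapiens) for antiproliferative activity, read by MTT assay, with a stated time of 48 h (on this read-out lower numbers stand for stronger inhibition and higher numbers for weaker inhibition), compound 1 `CCn1c(C(=O)NCCN)ccc1C(CC)(CC)c1ccc(OCCC(O)(CC)CC)c(C)c1` gives 1590 nM, and compound 2 `CCn1c(C(=O)N(CCC#N)CCC#N)ccc1C(CC)(CC)c1ccc(OCCC(O)(CC)CC)c(C)c1` gives 46300 nM, with a 29-fold higher number from compound 1 to compound 2 (1.46 log units; beyond the scatter). Compound 3 `CCOc1ccc(NC(=O)c2ccc(C(CC)(CC)c3ccc(OCCC(O)(CC)CC)c(C)c3)n2CC)cc1` is recorded only as a limit, > 50000 nM. Compound 4 `CCn1c(C(=O)NC(C)C(=O)O)ccc1C(CC)(CC)c1ccc(OCCC(O)(CC)CC)c(C)c1` differs from it by 1-carboxyethyl in place of 4-ethoxyphenyl on an amide-type nitrogen, with 1-carboxyethyl in place of 4-ethoxyphenyl on an amide-type nitrogen. Compound 1 also has a group without a ring there, and the closest guide is an at least 31-fold higher number from compound 1 to compound 3 (1.49 log units; beyond the scatter). Compound 2 goes against this pattern. Its group also lacks a ring, yet the data show an at least 1.0-fold higher number from compound 2 to compound 3 (0.03 log units; that floor lies within the scatter). A moderate change toward a lower number is therefore expected, and the estimated step is an at least 3.3-fold lower number from compound 3 to compound 4 (0.52 log units; beyond the scatter). For compound 4 the expected value is 15000 nM, with an estimated range of 3000 nM to 60000 nM.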

Compound 4, half-maximal inhibitory concentration: 1740 nM
Compound 4: middle estimate off by 8.6-fold (0.94 log units), on the high side, and the stated range ends above it.
By their numbers in this assay, from the lowest: compounds 1 and 4 (each within the scatter of the next); then compound 2. At a limit, above all of these: compound 3.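

In this assay, 1-carboxyethyl in place of 4-ethoxyphenyl on the amide-type nitrogen gives an at least 28-fold lower number from compound 3 to compound 4 (1.45 log units; beyond the scatter), and exchanging the group on the carbonyl carbon of compound 2 gives a 27-fold lower number from compound 2 to compound 4 (1.43 log units; beyond the scatter). The first of these steps rests on a limit for compound 3: the limit of > 50000 nM in this assay, at which 1 of the 4 values shown sits. The carboxylic acid chain and the 2-aminoethyl chain show a 1.1-fold higher number from compound 1 to compound 4 (0.04 log units; within the scatter), so two different ringless groups fall within the scatter, while ringless compound 2 goes against them. Going by these compounds, whether a methyl ester or a longer chain carrying the carboxylic acid would stay at this level remains open.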